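Methoxymethyl in place of ethyl on the aromatic tail

The source may report more compounds than this note shows. Statements on the series, on what has been measured and on what is new or still open speak of the compounds shown alone.

Compound 1 `O=C(O)CCCSCCN1C(=O)OC[C@@H]1/C=C/[C@@H](O)Cc1ccccc1`: > 10000 nM
Compound 2 `O=C(O)CCCSCCN1C(=O)OC[C@@H]1/C=C/[C@@H](O)Cc1cccc(C(F)(F)F)c1`: > 10000 nM
Compound 3 `CCc1cccc(C[C@H](O)/C=C/[C@H]2COC(=O)N2CCSCCCC(=O)O)c1`: 2400 nM

Of the compounds shown here, three sharing one core have been tested in an assay on CHO cells for displacement of a labelled ligand from prostaglandin E2 receptor EP1 subtype (Mus musculus), read by scintillation counting, with a stated time of 20 min; a higher number here means a weaker inhibitor, a lower number a stronger inhibitor. For compound 1 the result of > 10000 nM is a limit of the assay, not a number. Compound 2 likewise sits at a limit with > 10000 nM. Only compound 3 gives a real number, 2400 nM, so it is the sole measured point; the other two results rest at the limit of > 10000 nM in this assay, at which 2 of the 3 values shown sit.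

The measured steps concern the group on the aromatic carbon: an at least 4.1-fold lower number from compound 1 to compound 3 (0.61 log units; beyond the scatter) and an at least 4.1-fold lower number from compound 2 to compound 3 (0.61 log units; beyond the scatter), while a step that the two limits leave unreadable from compound 1 to compound 2. Ethyl on the aromatic carbon thus helps at least modestly compared with hydrogen or trifluoromethyl.

Compound 4 `COCc1cccc(C[C@H](O)/C=C/[C@H]2COC(=O)N2CCSCCCC(=O)O)c1` differs from compound 3 by methoxy in place of methyl on a saturated chain carbon bound to an aromatic carbon. Among the measured compounds shown here, no measured step tests this change; the known steps only show that a small carbon group on the aromatic carbon is favourable. Compound 4 is therefore expected to stay close to compound 3, with the estimated step of a 1.5-fold higher number from compound 3 to compound 4 (0.16 log units; within the scatter) inside the usual scatter. Compound 4 is expected to give 3500 nM, between 1000 nM and 12000 nM.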

Compound 4, inhibition constant: > 10000 nM
Compound 4 gave a limit, no number; the forecaster's own chance of this, stated with the estimate: 25%; middle value at least 2.8-fold (0.45 log units) away from the limit.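

Putting methoxy in place of the end methyl, which turns ethyl into methoxymethyl on the aromatic carbon, weakens binding in this assay, with an at least 4.1-fold higher number from compound 3 to compound 4 (0.61 log units; beyond the scatter). The earlier compounds showed only that ethyl did better than hydrogen or trifluoromethyl, which left room to think that almost any small chain carbon group would serve here; this result shows that a chain starting with the same kind of carbon on the aromatic ring does not necessarily keep the gain, so among the four groups shown only ethyl, in compound 3, gives a real number. The steps among compound 1, compound 2 and compound 4 cannot be read, as all three results are limits and not numbers: the limit of > 10000 nM in this assay, at which 3 of the 4 values shown sit.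

From the compounds shown here alone, how far compound 4 really lies past its limit stays unknown, so the true size of the loss is open. Going by these compounds, it is also open whether the oxygen itself or some other feature of methoxymethyl matters, and a propyl chain or a methyl group, or an aminomethyl group, on the same aromatic carbon would help to separate these possibilities.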